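The compounds below may be only part of what the source reports. "The series", "measured", "known", "first", "only" and "open" are said of these compounds alone.

Measured so far:
- compound 1, `COc1cc(C(=O)/C=C/c2ccc([N+](=O)[O-])cc2)cc(OC)c1OC`, > 100000 nM in a functional assay on B16 cells (Mus musculus) for cytotoxicity, read by MTT assay, with a stated time of 3 days; a higher number here means a weaker inhibitor, a lower number a stronger inhibitor
- compound 2, `COc1cc(C(=O)/C=C/c2ccc(N)cc2)cc(OC)c1OC`, 30000 nM in this assay
- compound 3, `COc1ccc(OC)c(C(=O)/C=C/c2ccc(OC)c([N+](=O)[O-])c2)c1`, > 100000 nM in this assay

For compound 1 the value is a limit of the assay, not a number. For compound 3 the value likewise is a limit of the assay. Only compound 2 gives a measured number in this assay. Between compound 1 and compound 2 one change is made, (amino in place of nitro on an aromatic carbon), and it brings an at least 3.3-fold lower number from compound 1 to compound 2 (0.52 log units; beyond the scatter). How large the step truly is cannot be said, because of the limit of > 100000 nM in this assay, at which 2 of the 3 values shown sit.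

Compound 3 has the same atoms as compound 1, joined differently; the difference between the two cores is not broken down here. Compound 4, `COc1ccc(OC)c(C(=O)/C=C/c2ccc(OC)c(N)c2)c1`, has not yet been measured. It differs from compound 3 by amino in place of nitro on an aromatic carbon. This is the same kind of change as that from compound 1 to compound 2, though the surroundings differ: in compound 2 the amino group sits para to a large group, in compound 4 it sits ortho to a methoxy group (2 heavy atoms) and meta to a large group.

For compound 4 in this assay a step of about an at least 2.0-fold lower number from compound 3 to compound 4 (0.30 log units; that floor lies within the scatter) is expected, resting on the step from compound 1 to compound 2, an at least 3.3-fold lower number from compound 1 to compound 2 (0.52 log units; beyond the scatter), with wide uncertainty since that step is itself only a lower bound. Compound 4 is therefore estimated at 50000 nM, with a likely range from 15000 nM to 150000 nM.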

Compound 4, half-maximal inhibitory concentration: 2000 nM
Beside the measured number, compound 4's estimate is 25-fold (1.40 log units) above it, outside the stated range (below it).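

In this assay the change of amino in place of nitro on an aromatic carbon brings a lower number on a second core, an at least 50-fold lower number from compound 3 to compound 4 (1.69 log units; beyond the scatter), so for these two pairs the direction of the step is the same on the core of compound 1 and on the core of compound 3. This agreement in direction does not show that the size of the step carries from one core to the other, and the two steps cannot be ranked against each other: the same change on two cores in this assay, an at least 3.3-fold lower number (0.52 log units; beyond the scatter) from compound 1 to compound 2 and an at least 50-fold lower number (1.69 log units; beyond the scatter) from compound 3 to compound 4; the limit leaves it open whether they differ. Going by these compounds, each step is only a floor and its true size remains unknown, since the nitro compound of each pair gives no measured number: the limit of > 100000 nM in this assay, at which 2 of the 4 values shown sit.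

The compounds shown leave open whether another group on the same aromatic carbon, such as a hydroxyl, an acetamide or a dimethylamino group, would give a lower or a higher number than the amino group of compound 4. Also open, on these data alone, is how much the methoxy group on that ring contributes to the 2000 nM of compound 4, and whether a simple hydrogen in its place would keep that value.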